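Ethoxy analogue of an inert octyloxy purine series

A few compounds are considered here, and "the series" means these few. Any claim that something is new, unique, unknown or untested is made for them only; others in the source may bear on it.

Measured values in an ADME assay on HFF cells (Homo sapiens) for cytotoxicity, with a stated time of 8 days; on this read-out higher numbers stand for lower toxicity in this test and lower numbers for higher toxicity in this test:
compound 1, `CCCCCCCCOc1nc(N)nc2c1ncn2/C=C1/CC1(CO)CO`, gives > 300000 nM, a limit of the assay.
compound 2, `CCCNc1nc(N)nc2c1ncn2/C=C1/CC1(CO)CO`, gives > 300000 nM, a limit of the assay.
compound 3, `CSc1nc(N)nc2c1ncn2/C=C1/CC1(CO)CO`, gives > 300000 nM, a limit of the assay.

Compound 1 stands only at a limit in this assay, and the two further compounds shown share that position, as the summary the limit of > 300000 nM in this assay, at which 3 of the 3 values shown sit, records. The steps that replace its octyloxy group, a step that the two limits leave unreadable from compound 1 to compound 2 and a step that the two limits leave unreadable from compound 1 to compound 3, cannot be read in size, since both ends sit at a limit; the same holds for a step that the two limits leave unreadable from compound 2 to compound 3.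

Compound 4, `CCOc1nc(N)nc2c1ncn2/C=C1/CC1(CO)CO`, has not yet been measured. It differs from compound 1 by hydrogen in place of hexyl on a saturated chain carbon, two bonds along the chain from an oxygen on an aromatic ring. Among the measured compounds shown here, no measured step bears directly on this shortening of the chain, and the steps that do change the same position give no readable size. For the measured compounds named here, the only guidance is that every compound measured so far rests at the limit of this assay. Compound 4 is therefore expected to give 300000 nM, with a likely range from 150000 nM to 600000 nM, most probably again reported only as a limit. The step of a number no higher from compound 1 to compound 4 (the limit leaves the size open) is estimated to lie within the scatter.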

Compound 4, half-maximal cytotoxic concentration: > 300000 nM
Compound 4: no number, only a limit (the forecaster's own chance of this, stated with the estimate: 85%); the middle value lies on the limit itself.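

In this assay compound 4 gives > 300000 nM, which is a limit of the assay. Among the compounds shown here, no step from compound 1, compound 2 or compound 3 to compound 4 can be read in size. The compounds shown leave open whether exchanging these groups changes the read-out at all, as all of them sit at one limit: the limit of > 300000 nM in this assay, at which 4 of the 4 values shown sit.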